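Piperazine nitrogen in the spiro amide series: removing methylsulfonyl

This account rests on a few compounds, and the source may have more. Where it says the series, first, only, none or still open, it means among the compounds named here.

Measured compounds:
- compound 1 `CCc1nn(CC)c(C2CCN(C(=O)CN3CN(c4ccccc4)C4(CCN(C(=O)c5ccc(C6CCCCC6)cc5)CC4)C3=O)CC2)c1C` — "not determined" (no result reported) in an assay on HEK293 cells for displacement of a labelled ligand from NPC1-like intracellular cholesterol transporter 1 (Homo sapiens); a higher number here means a weaker inhibitor, a lower number a stronger inhibitor
- compound 2 `CC(C)(C)OC(=O)NCCCNC(=O)CN1CN(c2ccccc2)C2(CCN(C(=O)c3ccc(C4CCCCC4)cc3)CC2)C1=O` — 6000 nM
- compound 3 `CC(C)(C)c1ccc(C(=O)N2CCC3(CC2)C(=O)N(CC(=O)N2CCN(S(C)(=O)=O)CC2)CN3c2ccccc2)cc1` — 19000 nM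

Compound 3 gives the highest number of the two that have been measured in this assay; the nearest entry, compound 2, sits lower, a gap that is beyond the usual scatter. Compound 1 carries no result, so compound 3 is set against one number only.

Compound 4 `CC(C)(C)c1ccc(C(=O)N2CCC3(CC2)C(=O)N(CC(=O)N2CCNCC2)CN3c2ccccc2)cc1` is the next point. It differs from compound 3 in one place: hydrogen in place of methylsulfonyl on an amine nitrogen in a ring. The ring nitrogen of compound 3 that bears the methylsulfonyl is left bare in compound 4, so the 4-(methylsulfonyl)piperazin-1-yl becomes piperazin-1-yl.

Among the measured compounds shown here, no pair of measured compounds shows what this kind of change does here, and the step from compound 2 to compound 3 involves several changes at once, so it cannot be read as a guide. The expectation is therefore a step of modest size, in either direction, most likely not beyond the scatter: a 1.3-fold lower number from compound 3 to compound 4 (0.10 log units; within the scatter) is the estimated step from compound 3 to compound 4. Compound 4 is estimated at 15000 nM, within a range of 5000 nM to 45000 nM.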

Compound 4, half-maximal inhibitory concentration: 22000 nM
Compound 4: the middle estimate sits 1.5-fold (0.17 log units) below what was measured, within the range that was stated.
By their numbers in this assay, from the lowest: compound 2; then compounds 3 and 4 (each within the scatter of the next).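

In this assay, among the compounds shown here, the first single-place step is a 1.2-fold higher number from compound 3 to compound 4 (0.06 log units; within the scatter), so compound 3 and compound 4 cannot be told apart. At this position, on the ring amine nitrogen, the methylsulfonyl can therefore be replaced by hydrogen with no shift beyond the scatter, and 4-(methylsulfonyl)piperazin-1-yl and piperazin-1-yl read alike in this one pair. No measurement at hand explains this result.

On these data alone, it remains open whether larger or different groups on the same nitrogen, such as an acetyl, a methyl or a benzyl, would also leave the number within the scatter of these two compounds. Also open, as far as these compounds go, is whether a cyclohexyl in place of the tert-butyl would leave this step as it is.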